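Swapping the cyano for halogens on the phenyl ring

This account rests on a few compounds, and the source may have more. Where it says the series, first, only, none or still open, it means among the compounds named here.

Compounds measured so far:
- compound 1 `Cn1c(CN2CCN(c3ccc(C(F)(F)F)cc3)CC2)nc2ccccc21`: 200 nM
- compound 2 `Cn1c(CN2CCN(c3ccccc3F)CC2)nc2ccccc21`: 794 nM
- compound 3 `Cn1c(CN2CCN(c3ccc(C#N)cc3)CC2)nc2ccccc21`: > 12500 nM

In an assay on CHO cells with metabotropic glutamate receptor 2 (Homo sapiens) as the target, read by FLIPR (on this read-out lower numbers stand for an effect already at smaller amounts and higher numbers for an effect only at larger amounts of compound), compound 3 reaches only a limit, > 12500 nM, and no number is known for it. The other two compounds have numbers: compound 1 gives 200 nM and compound 2 gives 794 nM. Both steps leading to compound 3 are large: an at least 62-fold higher number from compound 1 to compound 3 (1.79 log units; beyond the scatter) and an at least 15-fold higher number from compound 2 to compound 3 (1.19 log units; beyond the scatter). Compound 4 `Cn1c(CN2CCN(c3ccc(Cl)cc3F)CC2)nc2ccccc21` has not yet been measured. It differs from compound 3 in one place: 4-chloro-2-fluorophenyl in place of 4-cyanophenyl on an amine nitrogen in a ring. The two measured steps bear on this change in reverse, since both the trifluoromethyl of compound 1 and the 2-fluorophenyl of compound 2 gave far lower numbers than the 4-cyanophenyl of compound 3. Compound 4 carries a chlorine and a fluorine in place of the nitrile, so the number is expected to fall well beyond the scatter, as an at least 41-fold lower number from compound 3 to compound 4 (1.61 log units; beyond the scatter). The estimate for compound 4 is 300 nM, in the range 100 nM to 1500 nM.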

Compound 4, half-maximal effective concentration: 126 nM
The estimate for compound 4 lay 2.4-fold (0.38 log units) above the measured number; the measured number falls inside the stated range.
By their numbers in this assay, from the lowest: compounds 4 and 1 (each within the scatter of the next); then compound 2. At a limit, above all of these: compound 3.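

Compound 3 stands only at a limit of the assay, not at a number: the limit of > 12500 nM in this assay, at which 1 of the 4 values shown sits. In this assay, the change to 4-chloro-2-fluorophenyl on the amine nitrogen in the ring gives an at least 99-fold lower number from compound 3 to compound 4 (1.99 log units; beyond the scatter), so a phenyl ring without the nitrile and with two halogens reaches a low number. Going by these compounds alone, with the fluorine kept, chloro in place of hydrogen on an aromatic carbon gives a 6.3-fold lower number from compound 2 to compound 4 (0.80 log units; beyond the scatter), a modest step beyond the scatter, which the earlier compounds could not show, as none of them carried both halogens.

The compounds shown leave open whether a bromo, a methyl or a methoxy on that carbon would serve as the chloro does. They also leave open whether the fluoro is still needed once the chloro is present.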